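This account rests on a few compounds, and the source may have more. Where it says the series, first, only, none or still open, it means among the compounds named here.

- Compound 1 `N[C@H]1CC[C@H](Nc2c(C(=O)NCc3ccc(F)cc3)nc(N3CCCCS3(=O)=O)c3cccnc23)CC1`: > 10000 nM, a limit
- Compound 2 `Nc1cccc(Nc2c(C(=O)NCc3ccc(F)cc3)nc(Br)c3cccnc23)c1`: > 10000 nM, a limit
- Compound 3 `CN(C)CCCNc1c(C(=O)NCc2ccc(F)cc2)nc(Br)c2cccnc12`: > 10000 nM, a limit

All three compounds were tested in a functional assay on HCT-116 cells (Homo sapiens) for cytotoxicity, read by MTT assay, with a stated time of 72 h (on this read-out higher numbers stand for weaker inhibition and lower numbers for stronger inhibition), and none gave a number: the record shows (the limit of > 10000 nM in this assay, at which 3 of the 3 values shown sit). Compound 1 therefore has a limit as its only standing, and it cannot be ranked against the other two.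

Compound 4 `N[C@H]1CC[C@H](Nc2c(C(=O)NCc3ccc(F)cc3)nc(N3CCCCC3)c3cccnc23)CC1` has not yet been measured. It differs from compound 1 by a group of 6 heavy atoms (5 carbon, 1 nitrogen; one six-membered non-aromatic ring with 1 hetero atom) in place of a group of 8 heavy atoms (4 carbon, 1 nitrogen, 2 oxygen, 1 sulfur; one six-membered non-aromatic ring with 2 hetero atoms), on an aromatic carbon. The piperidin-1-yl group sits on an aromatic carbon, para to a (4-aminocyclohexyl)amino group.

Going by the values given here, the one measured step, a step that the two limits leave unreadable from compound 2 to compound 3, concerns a different group and offers no size to carry over. The limit for compound 1, > 10000 nM, leaves room for a readable change only toward stronger inhibition, so a modest move in that direction is expected, if any. The estimated step is an at least 1.6-fold lower number from compound 1 to compound 4 (0.22 log units; that floor lies within the scatter). For compound 4 the expected value is 6000 nM, with an estimated range of 1500 nM to 20000 nM.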

Compound 4, half-maximal inhibitory concentration: 8500 nM
Compound 4: middle estimate off by 1.4-fold (0.15 log units), on the low side; low and high end bracket the measured number.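

On an aromatic carbon para to a (4-aminocyclohexyl)amino group, piperidin-1-yl in place of the six-membered non-aromatic ring with 2 hetero atoms gives, in this assay, an at least 1.1-fold lower number from compound 1 to compound 4 (0.07 log units; that floor lies within the scatter). Compound 4 is the only compound shown with a number rather than a limit, at 8500 nM, so this one change yields the first value that can be read in this assay. The true size of the step stays unknown, and the step between the other two compounds cannot be read, as the record is dominated by a single limit: the limit of > 10000 nM in this assay, at which 3 of the 4 values shown sit.

The compounds shown leave open whether morpholin-4-yl or a simple amine at this place would move the number beyond the scatter from compound 4. They also leave open whether a longer chain in place of the (4-aminocyclohexyl)amino group would keep a readable value.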